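Bulkier thiocarbonyl amines in the series: compound 3 to compound 4

The source may hold more compounds than are shown below. What is called first, only, known or untested is meant among the compounds shown, and "the series" means these compounds.

Values in a functional assay on MGC-803 cells (Homo sapiens) for inhibition, read by CCK-8 assay, with a stated time of 48 h; on this read-out lower numbers stand for stronger inhibition and higher numbers for weaker inhibition:
- Compound 1 `COc1ccc(CN(C(=O)CSC(=S)N2CCOCC2)c2cc(OC)c(OC)c(OC)c2)cc1`: 2370 nM
- Compound 2 `COc1ccc(CN(C(=O)CSC(=S)N2CCCC2)c2cc(OC)c(OC)c(OC)c2)cc1`: > 20000 nM (a limit of the assay)
- Compound 3 `COc1ccc(CN(C(=O)CSC(=S)N2CCc3cc(Br)ccc32)c2cc(OC)c(OC)c(OC)c2)cc1`: > 20000 nM (a limit of the assay)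
- Compound 4 `COc1ccc(CN(C(=O)CSC(=S)N2CCCc3cc(C)ccc32)c2cc(OC)c(OC)c(OC)c2)cc1`: not yet measured

Compound 3 has no number of its own and stands at the limit of > 20000 nM in this assay, at which 2 of the 3 values shown sit. Its place in the series is therefore known only as a limit, which makes it a poor starting point for any step.

The change to follow is 6-methyl-1,2,3,4-tetrahydroquinolin-1-yl in place of 5-bromo-2,3-dihydro-1H-indol-1-yl on a thiocarbonyl carbon. For the measured compounds named here, the group entering on the thiocarbonyl carbon, 6-methyl-1,2,3,4-tetrahydroquinolin-1-yl, has not yet been seen.

Going by the values given here, two measured steps bear on it: an at least 8.4-fold higher number from compound 1 to compound 2 (0.92 log units; beyond the scatter), and an at least 8.4-fold higher number from compound 1 to compound 3 (0.92 log units; beyond the scatter). Both lie beyond the scatter and both leave morpholin-4-yl. Among these three compounds, only compound 1 gives a number, and none goes against that pattern. The third step is a step that the two limits leave unreadable from compound 2 to compound 3, so it sets no size.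

Compound 4 also lacks morpholin-4-yl, so it is expected to stay weak in this assay, with a limit as the likeliest report. No step beyond the scatter is expected, and no direction can be claimed. The expected step, as an estimate, is an at least 1.1-fold lower number from compound 3 to compound 4 (0.04 log units; that floor lies within the scatter). For compound 4 the estimated value is 18000 nM, with an expected range of 7000 nM to 30000 nM.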

Compound 4, half-maximal inhibitory concentration: 6490 nM
The estimate for compound 4 lay 2.8-fold (0.44 log units) above the measured number; measured number below the stated range.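

In this assay, placing 6-methyl-1,2,3,4-tetrahydroquinolin-1-yl on the thiocarbonyl carbon gives an at least 3.0-fold lower number from compound 3 to compound 4 (0.48 log units; beyond the scatter) when it replaces 5-bromo-2,3-dihydro-1H-indol-1-yl, and an at least 3.0-fold lower number from compound 2 to compound 4 (0.48 log units; beyond the scatter) when it replaces pyrrolidin-1-yl. Morpholin-4-yl is therefore no longer the only amine at this position that gives a number, although the exchange away from it still gives a 2.7-fold higher number from compound 1 to compound 4 (0.44 log units; beyond the scatter). The two gains are floors and not sizes, and the step between the two limits cannot be read: the limit of > 20000 nM in this assay, at which 2 of the 4 values shown sit.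

The change from compound 3 to compound 4 alters the ring and exchanges bromine for methyl in one move, so the compounds shown do not tell which of the two goes with the lower number. A 6-bromo-1,2,3,4-tetrahydroquinolin-1-yl group or an unsubstituted 1,2,3,4-tetrahydroquinolin-1-yl group on the same thiocarbonyl carbon would separate the two, and a piperidin-1-yl group would show how morpholin-4-yl fares against a ring without its oxygen.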